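From sec-butyl to phenyl on a shared core

This account rests on a few compounds, and the source may have more. Where it says the series, first, only, none or still open, it means among the compounds named here.

Values measured in a functional assay on MCF7 cells (Homo sapiens) for cytotoxicity, read by MTT assay, with a stated time of 48 h (a higher number here means a weaker inhibitor, a lower number a stronger inhibitor), are as follows.
Compound 1 `C=C[C@@]1(C)COC(=O)[C@]12OC([C@H](C)CC)=CC2=O` gives > 100 ug/mL as a limit
Compound 2 `C=C[C@@]1(C)COC(=O)C1(O)C(=O)/C=C(\O)c1ccccc1` gives 62.1 ug/mL as a number
Compound 3 `C=C[C@@]1(C)COC(=O)C1C(=O)/C=C(\O)c1ccccc1` gives 52.9 ug/mL as a number

Compound 1 stands at the limit of > 100 ug/mL in this assay, at which 1 of the 3 values shown sits, and that is a limit, not a number. Compound 4 `C=C[C@@]1(C)COC(=O)[C@]12OC(c1ccccc1)=CC2=O` has not been measured yet. Its change from compound 1 is phenyl in place of sec-butyl on a double-bonded ring carbon and in plain words this is phenyl in place of sec-butyl on a double-bonded ring carbon. Within the data shown here, the only measured step is a 1.2-fold lower number from compound 2 to compound 3 (0.07 log units; within the scatter) and it concerns a hydrogen in place of hydroxy, so it does not size this change. Compound 3 offers weak guidance, since it carries a phenyl, though not on the core of compound 1, and in this assay compound 3 gives 52.9 ug/mL as a number. A move towards a lower number is therefore expected, but with much uncertainty. The estimated step is an at least 1.4-fold lower number from compound 1 to compound 4 (0.15 log units; that floor lies within the scatter) in this assay on this reasoning. Compound 4 is expected near 70 ug/mL (estimated range 30 ug/mL to 130 ug/mL).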

Compound 4, half-maximal inhibitory concentration: 77.7 ug/mL
For compound 4 the middle estimate is 1.1-fold (0.05 log units) below the measured one; the range from low to high includes it.
By their numbers in this assay, from the lowest: compounds 3, 2 and 4 (each within the scatter of the next). At a limit, above all of these: compound 1.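

Placing phenyl instead of sec-butyl at this double-bonded ring carbon gives, in this assay, an at least 1.2-fold lower number from compound 1 to compound 4 (0.10 log units; that floor lies within the scatter). This is the first step shown at this position on the shared core, and compound 4 gives a true number of 77.7 ug/mL in a series where the core of compound 1 had so far offered none. Compound 1 sits at a limit and not at a number, so this step has only a floor, and its true size cannot be read: the limit of > 100 ug/mL in this assay, at which 1 of the 4 values shown sits.

As far as these compounds go, it remains open how the number would respond to other groups at this ring carbon, such as an amine, a carboxylic acid or a longer chain. With only sec-butyl and phenyl shown here, no trend can be drawn for this position.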